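A few compounds are considered here, and "the series" means these few. Any claim that something is new, unique, unknown or untested is made for them only; others in the source may bear on it.

In a functional assay on HL-60 cells (Homo sapiens) for cytotoxicity (a lower number here means a stronger inhibitor, a higher number a weaker inhibitor), compound 3 `CC1(C)CCC(C)(C)c2cc(/C=C\c3ccc(N)cc3)ccc21` gives 18000 nM. Two relatives were measured alongside it: compound 1 `CC1(C)CCC(C)(C)c2cc(/C=C/c3cccc(N)c3)ccc21` gives 20000 nM, and compound 2 `COc1ccc(/C=C\c2ccc3c(c2)C(C)(C)CCC3(C)C)cc1N` gives 25000 nM. All three numbers lie within the usual scatter of repeated measurements, so compound 3 cannot be told apart from the other two.

Compound 4 `CC1(C)CCC(C)(C)c2cc(/C=C\c3cccc(N)c3)ccc21` is the next structure to consider. It differs from compound 3 in one place, with 3-aminophenyl in place of 4-aminophenyl on a double-bonded chain carbon bound to a double-bonded chain carbon.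

Among the compounds with values here, no two measured compounds differ in only one place, so there is no direct guide to the size of this step. Within the data shown here, the only guide is the narrow spread of the measured set, with compound 3 at 18000 nM and compound 2 at 25000 nM. On that basis, no change beyond the scatter is expected in this assay. The expected result is a 1.1-fold higher number from compound 3 to compound 4 (0.05 log units; within the scatter). Compound 4 is estimated at 20000 nM, with an expected range of 11000 nM to 35000 nM.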

Compound 4, half-maximal inhibitory concentration: 10000 nM
For compound 4 the middle estimate is 2.0-fold (0.30 log units) above the measured one; measured number outside the range, below it.
By their numbers in this assay, from the lowest: compounds 4, 3, 1 and 2 (each within the scatter of the next, the first and the last beyond it).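

In this assay, swapping 4-aminophenyl for 3-aminophenyl on the double-bonded chain carbon does not clearly shift the number (a 1.8-fold lower number from compound 3 to compound 4 (0.26 log units; within the scatter)). Hydrogen in place of methoxy on an aromatic carbon gives the only step here that clears the scatter, and only modestly (a 2.5-fold lower number from compound 2 to compound 4 (0.40 log units; beyond the scatter)). The shape of the double bond can also be read by itself, and that step stays within the scatter too (a 2.0-fold lower number from compound 1 to compound 4 (0.30 log units; within the scatter)), a clean comparison of drawn configuration alone: the fact that compounds 1 and 4 differ only in the configuration as drawn.

Still open, as far as these compounds go, is how another group on that same aromatic carbon, such as a hydroxyl or a chlorine, would compare with methoxy and hydrogen. Also open, from the compounds shown here alone, is whether an acetamide in place of the amine would move the number at all.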